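Halting compounds: carbonyl-linked aryl variation, compound 4

A few compounds are considered here, and "the series" means these few. Any claim that something is new, unique, unknown or untested is made for them only; others in the source may bear on it.

Measured so far:
Compound 1 `COc1cc(-c2nn(-c3cccc(NC(=O)Nc4ccc(Cl)c(Cl)c4)c3)cc2-c2ccncc2)ccc1Cl` gives 1470 nM in a functional assay on HOP-92 cells (Homo sapiens) for inhibition, read by sulforhodamine B assay, with a stated time of 48 h; a lower number here means a stronger inhibitor of growth, a higher number a weaker inhibitor of growth.
Compound 2 `COc1cc(-c2nn(-c3cccc(NC(=O)c4ccc(Cl)c(C(F)(F)F)c4)c3)cc2-c2ccncc2)ccc1Cl` gives 3230 nM in this assay.
Compound 3 `COc1cc(-c2nn(-c3cccc(NC(=O)Nc4ccc(Cl)c(C(F)(F)F)c4)c3)cc2-c2ccncc2)ccc1Cl` gives 1480 nM in this assay.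

Compound 3 stands second highest of the three numbers; its nearest neighbour is compound 1, a difference that is within the scatter, and its furthest is compound 2.

Compound 4 `COc1cc(-c2nn(-c3cccc(NC(=O)c4ccccc4)c3)cc2-c2ccncc2)ccc1Cl` is the next structure. The change from compound 3 is phenyl in place of (4-chloro-3-(trifluoromethyl)phenyl)amino on a carbonyl carbon. Two things happen at once: the amino link between the carbonyl carbon and the aryl ring is removed, and the chloro and trifluoromethyl groups of that ring are lost.

Going by the values given here, the steps that bear on the first part are a 2.2-fold lower number from compound 2 to compound 3 (0.34 log units; beyond the scatter) and a 2.2-fold higher number from compound 1 to compound 2 (0.34 log units; beyond the scatter): removing the amino link raised the number in both cases, a modest step beyond the scatter. Among the compounds with values here, no measured step speaks to the loss of the chloro and trifluoromethyl groups, so that part is open. Compound 4 is therefore expected to give a higher number than compound 3, with the step of a 3.0-fold higher number from compound 3 to compound 4 (0.48 log units; beyond the scatter) likely at least as large as the measured amino-link steps. The estimate for compound 4 in this assay is 4500 nM, with a range from 2000 nM to 12000 nM.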

Compound 4, concentration for total growth inhibition: 4710 nM
Estimate against measurement, compound 4: 1.0-fold (0.02 log units) below, within the range that was stated.
By their numbers in this assay, from the lowest: compounds 1 and 3 (each within the scatter of the next); then compounds 2 and 4 (each within the scatter of the next).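

Loss of the chloro and trifluoromethyl groups can now be read on its own at this position: in this assay the change from the substituted ring to phenyl, with no amino link present, gives a 1.5-fold higher number from compound 2 to compound 4 (0.16 log units; within the scatter) and stays within the scatter. Removing the amino link and the ring groups together gives a 3.2-fold higher number from compound 3 to compound 4 (0.50 log units; beyond the scatter) and likewise a 3.2-fold higher number from compound 1 to compound 4 (0.51 log units; beyond the scatter) with both steps beyond the scatter. Among these four compounds, then, the amino link tracks with the lower numbers, while the two ring groups show no readable effect in the pair without the link. No measurement here explains these steps.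

Whether the ring groups matter when the amino link is kept remains open, as a phenylamino group on the carbonyl carbon is not among these compounds. Also open, on these data alone, is how a methoxy group, a morpholine or a carboxylic acid on that ring would behave.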